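A few compounds are considered here, and "the series" means these few. Any claim that something is new, unique, unknown or untested is made for them only; others in the source may bear on it.

Measured compounds:
compound 1 `C=C1C(=O)[C@]23C[C@@]1(O)CC[C@H]2c1ccc(OS(=O)(=O)c2ccc(C)cc2)c(C)c1[C@@H]3Cn1cc(-c2ccc(Cl)cc2)nn1`, 1870 nM
compound 2 `C=C1C(=O)[C@]23C[C@@]1(O)CC[C@H]2c1ccc(OS(=O)(=O)c2ccc(C)cc2)c(C)c1[C@@H]3Cn1cc(-c2ccc(F)cc2)nn1`, 1950 nM

In a functional assay on A549 cells (Homo sapiens) for cytotoxicity, read by MTT assay, with a stated time of 4 days (a lower number here means a stronger inhibitor, a higher number a weaker inhibitor), compound 1 gives 1870 nM and compound 2 gives 1950 nM. These two numbers sit within the scatter of each other, so neither compound can be called the stronger: the step of a 1.0-fold higher number from compound 1 to compound 2 (0.02 log units; within the scatter) shows that exchanging chloro for fluoro on the aromatic carbon of the pendant ring left this assay essentially unchanged.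

Compound 3 `C=C1C(=O)[C@]23C[C@@]1(O)CC[C@H]2c1ccc(OS(=O)(=O)c2ccc(C)cc2)c(C)c1[C@@H]3Cn1cc(-c2ccc(OC)cc2)nn1` is the next member of the series. It differs from compound 2 by methoxy in place of fluoro on an aromatic carbon. Going by the values given here, the only measured step that bears on this position is the one between compound 1 and compound 2, and that step, a 1.0-fold higher number from compound 1 to compound 2 (0.02 log units; within the scatter), was within the scatter. No measured compound carries a methoxy group, so the effect of an oxygen-bearing substituent at this carbon is not shown by the data and the range must be set wider than for a halogen swap. On the basis of the step of a 1.0-fold higher number from compound 1 to compound 2 (0.02 log units; within the scatter) alone, compound 3 is expected to show a step of a 1.0-fold higher number from compound 2 to compound 3 (0.01 log units; within the scatter), that is, no change beyond the scatter. Compound 3 is therefore estimated at 2000 nM, within 900 nM to 4500 nM.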

Compound 3, half-maximal inhibitory concentration: 1470 nM
Estimate against measurement, compound 3: 1.4-fold (0.13 log units) above; low and high end bracket the measured number.
By their numbers in this assay, from the lowest: compounds 3, 1 and 2 (each within the scatter of the next).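

In this assay the step of a 1.3-fold lower number from compound 2 to compound 3 (0.12 log units; within the scatter) and the step of a 1.3-fold lower number from compound 1 to compound 3 (0.10 log units; within the scatter) extend what the halogen swap alone could show: the number stays within the scatter not only when one halogen replaces another, but also when methoxy, a group of a different kind with a hydrogen-bond acceptor by the structural count, replaces either halogen on this aromatic carbon, para to a large group. The 4-chlorophenyl, 4-fluorophenyl and 4-methoxyphenyl compounds therefore cannot be told apart in this assay, and these three groups give no ranking at this position. No measurement is available that would explain this lack of separation.

The compounds shown leave open whether a different kind of group on this carbon, such as an amine, a carboxylic acid or a longer alkoxy chain, would move the number beyond the scatter. They also leave open how a plain phenyl ring, with only hydrogen on this carbon, would compare with the three compounds shown here.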